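Dichlorophenyl in place of naphthyl on a sulfonamide diamine

The source may hold more compounds than are shown below. What is called first, only, known or untested is meant among the compounds shown, and "the series" means these compounds.

The measured compounds are:
compound 1, `O=S(=O)(NCCCNCc1cccc2ccccc12)c1cc(C(F)(F)F)cc(C(F)(F)F)c1`, 2700 nM;
compound 2, `O=S(=O)(NCCCNCc1ccc(C(F)(F)F)cc1)c1cc(C(F)(F)F)cc(C(F)(F)F)c1`, 3200 nM;
compound 3, `O=S(=O)(NCCCNCc1ccccc1Cl)c1cc(C(F)(F)F)cc(C(F)(F)F)c1`, 15000 nM.

In a functional assay on PANC-1 cells (Homo sapiens) for inhibition, read by MTT assay, with a stated time of 72 h (a higher number here means a weaker inhibitor of growth, a lower number a stronger inhibitor of growth), compound 1 gives the lowest of the three numbers. Compound 2 sits close to it, a 1.2-fold higher number from compound 1 to compound 2 (0.07 log units; within the scatter), so these two cannot be told apart. Compound 3 stands further off: a 5.6-fold higher number from compound 1 to compound 3 (0.74 log units; beyond the scatter), and a 4.7-fold higher number from compound 2 to compound 3 (0.67 log units; beyond the scatter). Among the three, only the 2-chlorophenyl compound falls clearly out of the group.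

Compound 4, `O=S(=O)(NCCCNCc1ccc(Cl)c(Cl)c1)c1cc(C(F)(F)F)cc(C(F)(F)F)c1`, has not yet been measured. It differs from compound 1 as follows: 3,4-dichlorophenyl in place of naphthalen-1-yl on a saturated chain carbon bound to an amine nitrogen. The same change of the group on the saturated chain carbon bound to an amine nitrogen was followed twice from compound 1: to the 4-(trifluoromethyl)phenyl of compound 2 it made no difference beyond the scatter, while to the 2-chlorophenyl of compound 3 it gave a modest loss. The 3,4-dichlorophenyl of compound 4 is a single substituted ring, as in both compounds 2 and 3, so the two precedents pull in different directions, with the smaller step seeming the more likely guide. Compound 4 is therefore expected to stay near compound 1, a 1.3-fold higher number from compound 1 to compound 4 (0.11 log units; within the scatter), within the scatter. The estimate for compound 4 is 3500 nM, with a range from 1500 nM to 9000 nM.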

Compound 4, concentration for 50% growth inhibition: 5600 nM
For compound 4 the middle estimate is 1.6-fold (0.20 log units) below the measured one; the measured number falls inside the stated range.
By their numbers in this assay, from the lowest: compounds 1, 2 and 4 (each within the scatter of the next, the first and the last beyond it); then compound 3.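

In this assay, the 3,4-dichlorophenyl group shows that replacing naphthalen-1-yl with a single ring bearing two chlorines costs only a modest loss (a 2.1-fold higher number from compound 1 to compound 4 (0.32 log units; beyond the scatter)). The chlorine-bearing rings also differ from each other (a 2.7-fold lower number from compound 3 to compound 4 (0.43 log units; beyond the scatter)), so on this saturated chain carbon bound to an amine nitrogen, the number depends on which chlorinated ring is attached and not simply on the presence of chlorine. The new ring cannot be told apart from the 4-(trifluoromethyl)phenyl group (a 1.8-fold higher number from compound 2 to compound 4 (0.24 log units; within the scatter)), and compound 2 is now the one exception among the single rings, the only one still within the scatter of compound 1.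

The compounds shown leave open whether a 4-chlorophenyl or a 3-chlorophenyl group would stay with compound 2 and compound 4 or fall toward compound 3, and whether a naphthalen-2-yl group would match compound 1. Nothing available here speaks to what lies behind these differences among the rings.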